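The compounds below may be only part of what the source reports. "The series", "measured", "known", "first", "only" and "open" are said of these compounds alone.

Measured compounds:
- compound 1 `Cc1c(C(=O)/C=C/c2cccc([N+](=O)[O-])c2)[n+]([O-])c2ccccc2[n+]1[O-]`: 34000 nM
- compound 2 `COc1ccc(/C=C/C(=O)c2c(C)[n+]([O-])c3ccccc3[n+]2[O-])cc1`: 20000 nM
- compound 3 `Cc1c(C(=O)/C=C/c2ccc(Cl)cc2)[n+]([O-])c2ccccc2[n+]1[O-]`: 13000 nM

All three were tested in a functional assay on HSC-2 cells (Homo sapiens) for cytotoxicity, with a stated time of 48 h; on this read-out lower numbers stand for higher toxicity in this test and higher numbers for lower toxicity in this test. In this assay compound 2 gives 20000 nM, the second highest of the three numbers; yet its nearest neighbour, compound 3, differs from it by a 1.5-fold lower number from compound 2 to compound 3 (0.19 log units; within the scatter), and its furthest neighbour, compound 1, differs from it by an amount that is also within the scatter, so no ordering among the three can be claimed.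

Compound 4 `Cc1c(C(=O)/C=C/c2ccc(F)cc2)[n+]([O-])c2ccccc2[n+]1[O-]` is the next member of the series and has not yet been measured. It differs from compound 2 in one place: fluoro in place of methoxy on an aromatic carbon. Within the data shown here, the only measured step that bears on this change is the one from compound 2 to compound 3, where a chloro replaced the same methoxy on the same aromatic carbon and the number moved by a 1.5-fold lower number from compound 2 to compound 3 (0.19 log units; within the scatter), a step within the scatter. On that basis no step beyond the scatter is expected in this assay when the methoxy is replaced by fluoro either. Compound 4 is therefore expected to give 17000 nM, with a range from 8000 nM to 40000 nM. This estimate corresponds to an expected step of a 1.2-fold lower number from compound 2 to compound 4 (0.07 log units; within the scatter).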

Compound 4, half-maximal cytotoxic concentration: 6200 nM
For compound 4 the middle estimate is 2.7-fold (0.44 log units) above the measured one, outside the stated range (below it).
By their numbers in this assay, from the lowest: compound 4; then compounds 3, 2 and 1 (each within the scatter of the next, the first and the last beyond it).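

In this assay the change from 4-methoxyphenyl to 4-fluorophenyl gives a 3.2-fold lower number from compound 2 to compound 4 (0.51 log units; beyond the scatter) and so shows that a replacement at this aromatic carbon, para to a large group, can move the number beyond the scatter, which the step from compound 2 to compound 3 had not shown. The identity of the halogen also matters in this test, since the exchange of chloro for fluoro at the same carbon gives a 2.1-fold lower number from compound 3 to compound 4 (0.32 log units; beyond the scatter) and the two halogens therefore cannot be treated as interchangeable here. Both steps are modest, and no information at hand accounts for the separate standing of compound 4.

The compounds shown leave open whether a bromo group, a trifluoromethyl group or an amine at this same carbon would fall with fluoro, with chloro or elsewhere, and whether the unsubstituted phenyl would differ from any of them. They also leave open whether fluoro on another carbon of this ring would give a step of similar size, since the only other placement shown carries a nitro group.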